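The source may hold more compounds than are shown below. What is called first, only, known or untested is meant among the compounds shown, and "the series" means these compounds.

Working notes on the series in an assay on HEK293 cells for positive allosteric modulation of metabotropic glutamate receptor 3 (Rattus norvegicus), read by thallium flux, with a stated time of 2.5 min; a higher number here means that more compound is needed for the effect, a lower number that less compound is needed. Compound 1 `COc1cc(C(=O)O)ccc1OCCCCOc1ccc(C(=O)CC(C)(C)C)c(O)c1C` gives 310 nM in this assay, and compound 3 `Cc1c(OCCCCOc2ccc(C(=O)CC(C)(C)C)c(O)c2C)cccc1C(=O)O` gives 300 nM. Compound 2 `COc1cc(C(=O)O)ccc1OCCCCOc1ccc(C(=O)CC(C)C)c(O)c1C` shares the core of compound 1 and differs from it by hydrogen in place of methyl on a saturated chain carbon bound to three saturated chain carbons; compound 2 gives 614 nM. The step between them is a 2.0-fold higher number from compound 1 to compound 2 (0.30 log units; within the scatter). Compound 2 thus carries the highest number of the three: its distance to compound 1 is within the scatter, while compound 3 sits at a lower number beyond it. Compounds 1 and 3 differ in more than one place, so only their two values are compared, and they lie close together.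

Compound 4 `Cc1c(OCCCCOc2ccc(C(=O)O)cc2Cl)ccc(C(=O)CC(C)C)c1O` is the next step from compound 2: chloro in place of methoxy on an aromatic carbon. The change sits ortho to a large group and meta to a carboxy group. For the measured compounds named here, no measured pair alters this position; the one measured step, from compound 1 to compound 2, concerns the saturated chain and does not bear on an aromatic substituent. The expectation for this assay therefore rests on the lack of precedent rather than on a trend: a step of a 1.1-fold higher number from compound 2 to compound 4 (0.02 log units; within the scatter) is estimated, with no direction claimed beyond the scatter. Compound 4 is expected to give 650 nM, within a range of 200 nM to 2100 nM.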

Compound 4, half-maximal effective concentration: 1140 nM
For compound 4 the middle estimate is 1.8-fold (0.24 log units) below the measured one; the range from low to high includes it.
By their numbers in this assay, from the lowest: compounds 3, 1, 2 and 4 (each within the scatter of the next, the first and the last beyond it).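

In this assay, the aromatic carbon ortho to a large group and meta to a carboxy group now has its first measured exchange, and the step for chloro in place of methoxy stays small (a 1.9-fold higher number from compound 2 to compound 4 (0.27 log units; within the scatter)). One heavy atom enters where two leave and the count of hydrogen-bond acceptors on this group falls from one to none, yet the printed step does not separate the two compounds beyond the usual scatter of the assay, so this pair gives no sign that the position responds to this exchange. Alongside the chain change (a 2.0-fold higher number from compound 1 to compound 2 (0.30 log units; within the scatter)), this means that both single-place steps in the series, one on the saturated chain and one on the aromatic carbon, lie within the scatter, and no measurement shown gives a reason for the size of either.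

The compounds shown leave open whether a different group on this aromatic carbon, such as an amine, a hydroxyl or a longer ether chain, would give a step beyond the scatter. They also leave open whether chloro in place of methoxy would give a similar step on the core of compound 1, with its additional methyl on the saturated chain.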